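The compounds below may be only part of what the source reports. "The series", "measured", "known", "first", "only" and "open" are said of these compounds alone.

Compound 1 `CC1(C)Oc2ccc(C#N)cc2[C@@H](n2cccc2)[C@@H]1O`: in a functional assay (Trachealis) for inhibition, with Cavia porcellus as the target (on this read-out higher numbers stand for weaker inhibition and lower numbers for stronger inhibition), compound 1 gives only a limit, > 20000 nM.
Compound 2 `CC1(C)Oc2ccc(C#N)cc2[C@@H](n2cccc2[N+](=O)[O-])[C@@H]1O`: compound 2 gives 370 nM.
Compound 3 `CC1(C)C=C(n2cccc2[N+](=O)[O-])c2cc(C#N)ccc2O1`: compound 3 gives 690 nM.

Among the two numbers proper, compound 2 stands lowest, with compound 3 nearest to it; the gap between compound 2 and compound 3 lies within the scatter, so no order between them can be claimed. Compound 1 sits at the limit of > 20000 nM in this assay, at which 1 of the 3 values shown sits.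

Compound 4 `CC1(C)Oc2ccc(C#N)cc2[C@@H](n2cccc2C(=O)C(F)(F)F)[C@@H]1O` differs from compound 2 in one place: (trifluoromethyl)carbonyl in place of nitro on an aromatic carbon. Going by the values given here, no measured step exchanges one such group for another. Among the compounds with values here, the only step that touches this position is an at least 54-fold lower number from compound 1 to compound 2 (1.73 log units; beyond the scatter), which shows that what sits on that aromatic carbon can move the number a long way. Whether the (trifluoromethyl)carbonyl group holds the number where the nitro group does is not known from these compounds, so the expected step is modest but uncertain: the estimate for compound 4 implies a 2.2-fold higher number from compound 2 to compound 4 (0.33 log units; beyond the scatter). Compound 4 is therefore expected to give about 800 nM, within the range 150 nM to 4000 nM.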

Compound 4, half-maximal inhibitory concentration: > 20000 nM
Compound 4: no number, only a limit (the forecaster's own chance of this, stated with the estimate: 10%); middle value at least 25-fold (1.39 log units) from the limit.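

Exchanging the nitro group on this aromatic carbon, next to the ring nitrogen, for (trifluoromethyl)carbonyl in this assay gives an at least 54-fold higher number from compound 2 to compound 4 (1.73 log units; beyond the scatter). The earlier step showed only that nitro differs greatly from hydrogen here; this one shows that a group on this carbon is not enough in itself, since the identity of the group decides whether a number can be read at all. Compound 4 gives only a limit, and with compound 1 also at a limit, the step between compound 1 and compound 4 cannot be read: the limit of > 20000 nM in this assay, at which 2 of the 4 values shown sit.

The compounds shown do not tell what it is about nitro that sets it apart from the two other substituents here. Going by these compounds, whether an acetyl group, a carboxylic acid or an amine on this carbon would give a readable number remains open, as does the outcome of the same exchange on the core of compound 3.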